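Ether in place of the amino alcohol on the shared core

A few compounds are considered here, and "the series" means these few. Any claim that something is new, unique, unknown or untested is made for them only; others in the source may bear on it.

Within the data shown here, in an in vitro assay on 293-EBNA cells for binding affinity to corticotropin-releasing factor receptor 1 (Homo sapiens) (on this read-out higher numbers stand for weaker inhibition and lower numbers for stronger inhibition), compound 2 `CCC(CO)Nc1nc(C)nc2c1nnn2-c1ccc(C(C)C)cc1Br` gives 25.3 nM, the lowest of the two numbers so far. Compound 1 `Cc1nc(N2CCCC2)c2nnn(-c3ccc(C(C)C)cc3Br)c2n1` gives 194 nM in this assay. Among the measured compounds shown here, the only step, a 7.7-fold lower number from compound 1 to compound 2 (0.88 log units; beyond the scatter), swaps one nitrogen substituent for another. Compound 3 `COCC(COC)Oc1nc(C)nc2c1nnn2-c1ccc(C(C)C)cc1Br` carries a group of 8 heavy atoms (5 carbon, 3 oxygen; no ring) in place of a group of 6 heavy atoms (4 carbon, 1 nitrogen, 1 oxygen; no ring), on an aromatic carbon. For the measured compounds named here, no measured step bears directly on this exchange, since a 7.7-fold lower number from compound 1 to compound 2 (0.88 log units; beyond the scatter) does not involve an ether, so the direction of the change is open and only the span of the two measured values guides the expectation. Relative to compound 2, compound 3 is expected to show a 1.6-fold higher number from compound 2 to compound 3 (0.20 log units; within the scatter), with an estimated 40 nM (range 8 nM to 200 nM).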

Compound 3, inhibition constant: 7.1 nM
The estimate for compound 3 lay 5.6-fold (0.75 log units) above the measured number; measured number outside the range, below it.
By their numbers in this assay, from the lowest: compound 3; then compound 2; then compound 1.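

On the aromatic carbon next to the ring nitrogen, a hydrogen-bond donor is not required for a low number in this assay: the oxygen-linked group, with 0 hydrogen-bond donors, gives a 3.6-fold lower number from compound 2 to compound 3 (0.55 log units; beyond the scatter). Against the ring amine, the same group gives a 27-fold lower number from compound 1 to compound 3 (1.44 log units; beyond the scatter), the largest step in the set. No measurement here explains either step. The link atom and the side chain change together, so their contributions remain unseparated. A simple isopropyl ether, or an amine carrying the same two methoxymethyl arms, would address that question.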